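Three amide variants and a chloromethyl successor

The source may hold more compounds than are shown below. What is called first, only, known or untested is meant among the compounds shown, and "the series" means these compounds.

Compound 1, `CCCC(=O)Nc1ccc(S(=O)(=O)Oc2ccccc2C(C)C)cc1`, gave 6100 nM in a functional assay on M21 cells (Homo sapiens) for antiproliferative activity, read by sulforhodamine B assay, with a stated time of 48 h; on this read-out higher numbers stand for weaker inhibition and lower numbers for stronger inhibition.
Compound 2, `CC(C)C(=O)Nc1ccc(S(=O)(=O)Oc2ccccc2C(C)C)cc1`, gave 11000 nM in this assay.
Compound 3, `CC(C)c1ccccc1OS(=O)(=O)c1ccc(NC(=O)C(C)(C)C)cc1`, gave 6200 nM in this assay.

Compound 3 sits among three numbers that all lie within the scatter of one another: the three steps, a 1.8-fold higher number from compound 1 to compound 2 (0.26 log units; within the scatter), a 1.0-fold higher number from compound 1 to compound 3 (0.01 log units; within the scatter) and a 1.8-fold lower number from compound 2 to compound 3 (0.25 log units; within the scatter), are all small. Compound 4, `CC(C)c1ccccc1OS(=O)(=O)c1ccc(NC(=O)CCl)cc1`, carries the change (chloromethyl in place of tert-butyl on a carbonyl carbon). Within the data shown here, no measured step involves a chloromethyl group, so the only guidance is that altering the alkyl group on the carbonyl carbon has so far moved nothing beyond the scatter. On that basis compound 4 is expected to show a 1.0-fold lower number from compound 3 to compound 4 (0.01 log units; within the scatter), with an estimated value of 6000 nM and a range from 1500 nM to 24000 nM.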

Compound 4, half-maximal inhibitory concentration: 3900 nM
For compound 4 the middle estimate is 1.5-fold (0.19 log units) above the measured one, within the range that was stated.
By their numbers in this assay, from the lowest: compounds 4, 1, 3 and 2 (each within the scatter of the next, the first and the last beyond it).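

Among these compounds, on the carbonyl carbon, chloromethyl gives the only step beyond the scatter in this set, and a modest one: a 2.8-fold lower number from compound 2 to compound 4 (0.45 log units; beyond the scatter). Against the other two groups it stays within the scatter, with a 1.6-fold lower number from compound 3 to compound 4 (0.20 log units; within the scatter) and a 1.6-fold lower number from compound 1 to compound 4 (0.19 log units; within the scatter), so the separation holds against isopropyl alone. No measured evidence here explains this difference. On these data alone, it remains open whether a bromomethyl or aminomethyl group on the same carbonyl carbon would move the number in this assay beyond the scatter from compound 3 .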